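This account rests on a few compounds, and the source may have more. Where it says the series, first, only, none or still open, it means among the compounds named here.

Three compounds built on a shared core were compared in an assay on HL-60 cells for inhibition of glutathione S-transferase P (Homo sapiens), read by spectrophotometry, tested at 20 uM; a lower number here means less inhibition, a higher number more inhibition at the concentration tested (going by the name of the read-out). Compound 1 `Cc1cccc2c1N(CC(=O)O)C/C(=C\c1ccc(F)cc1)C2=O` gives 22.9% in this assay, the lowest of the three numbers. Compound 2 `COc1cc(/C=C2\CN(CC(=O)O)c3ccc(C)cc3C2=O)cc(OC)c1` gives 23.8% in this assay, a number that sits within the usual scatter of the value of compound 1, so the two cannot be separated. Compound 3 `CCOc1ccc(/C=C2\CN(CC(=O)O)c3c(Cl)cccc3C2=O)cc1` gives 59.1% in this assay, a number that lies beyond the scatter above compound 1.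

Compound 4 `Cc1cccc2c1N(CC(=O)O)C/C(=C\c1ccccc1)C2=O` has not yet been measured in this assay. It differs from compound 1 in a single place: hydrogen in place of fluoro on an aromatic carbon. Going by the values given here, no pair of measured compounds differs in just this way, so no measured step can be used as a guide. The change leaves the core untouched and removes only one fluorine, and the expected step of a number 0.9 percentage points lower from compound 1 to compound 4 (within the scatter) is accordingly small, with no movement beyond the scatter in either direction. Compound 4 is therefore estimated at 22% in this assay, with a range from 10% to 36%.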

Compound 4, a percentage reported as inhibition, at one concentration (the size of the read-out at that concentration, not a potency): 27.9%
Compound 4: the middle estimate sits 5.9 percentage points below what was measured, and the stated range covers the measured number.
By their numbers in this assay, from the lowest: compounds 1, 2 and 4 (each within the scatter of the next); then compound 3.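

Replacing fluoro with hydrogen on the aromatic carbon gives, in this assay, a number 5 percentage points higher from compound 1 to compound 4 (within the scatter), so the two compounds cannot be separated. Going by these compounds alone, this is the first direct reading of this position: on the core of compound 1, the 4-fluorophenyl and phenyl groups give numbers that the assay does not tell apart, so the fluorine is not needed to hold the number at this level. Nothing among the data shown accounts for this result.

On these data alone, the step covers only fluoro and hydrogen, so it remains open whether a larger or differently built group at this place, such as a nitrile, an amine or a carboxylic acid, would move the number beyond the scatter. As far as these compounds go, it also remains open whether the same exchange would be as small on a compound with a different substitution elsewhere on the shared core.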